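Hydrazinyl phthalazine series: thiourea substitution and antiproliferative activity

The source may report more compounds than this note shows. Statements on the series, on what has been measured and on what is new or still open speak of the compounds shown alone.

Measured compounds:
- compound 1, `O=C1CS/C(=N/Nc2nncc3ccccc23)N1c1ccccc1`: 56 nM
- compound 2, `NC(=S)NNc1nncc2ccccc12`: 37 nM
- compound 3, `O=S(=O)(Nc1ccccn1)c1ccc(Nc2nncc3ccccc23)cc1`: 26 nM

Three compounds sharing the hydrazinyl- or amino-linked core have been run in a functional assay on HeLa cells (Homo sapiens) for antiproliferative activity, read by sulforhodamine B assay, with a stated time of 72 h; on this read-out higher numbers stand for weaker inhibition and lower numbers for stronger inhibition. Compound 1 gives 56 nM, compound 2 gives 37 nM and compound 3 gives 26 nM. On these numbers compound 2 stands second highest of the three; its nearest neighbour is compound 3 and its furthest is compound 1, and both of those gaps fall within the usual scatter of this assay, so no ordering among the three can be claimed. For the measured compounds named here, no single-point step between measured compounds is available.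

The next compound, compound 4, `S=C(NNc1nncc2ccccc12)Nc1ccccc1`, differs from compound 2 in one place: phenyl in place of hydrogen on an amide-type nitrogen. The same difference, cut one bond further out, reads amino to anilino. Compound 1 carries a phenyl on the nitrogen of its cyclised thiocarbonyl-derived core and compound 3 carries an aryl amine, and neither of those values separates from compound 2 beyond the scatter. The step from compound 2 to compound 4 is therefore expected to be small, in either direction, and is estimated as a 1.1-fold higher number from compound 2 to compound 4 (0.03 log units; within the scatter). For compound 4 in this assay the estimate is 40 nM, with an expected range from 15 nM to 110 nM.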

Compound 4, half-maximal inhibitory concentration: 39 nM
Compound 4: the middle estimate sits 1.0-fold (0.01 log units) above what was measured, and the stated range covers the measured number.
By their numbers in this assay, from the lowest: compounds 3, 2, 4 and 1 (each within the scatter of the next, the first and the last beyond it).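

In this assay the series now has its first single-place comparison: phenyl in place of hydrogen on an amide-type nitrogen whose other neighbour is the thiocarbonyl carbon gives a 1.1-fold higher number from compound 2 to compound 4 (0.02 log units; within the scatter), so the amino to anilino change does not separate the two compounds. For the compounds shown here, this nitrogen therefore carries an added six-membered aromatic ring of carbon only with no shift that can be told from the scatter, which the earlier compounds could not show, as they differ from one another in more than one place. Nothing in the data available bears on the reason for this result.

On these data alone, this rests on a single replacement, so it remains open whether a methyl, a benzyl or a longer alkyl chain on the same nitrogen would also stay within the scatter of compound 2. Also open, as far as these compounds go, is whether a phenyl carrying a chlorine, a methoxy group or a carboxylic acid would hold that level, or whether a substituent on this nitrogen can move the number beyond the scatter at all.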